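Methoxy to hydroxy on compound 1

A few compounds are considered here, and "the series" means these few. Any claim that something is new, unique, unknown or untested is made for them only; others in the source may bear on it.

In a functional assay on MCF7 cells (Homo sapiens) for antiproliferative activity, read by MTT assay, with a stated time of 48 h (a higher number here means a weaker inhibitor, a lower number a stronger inhibitor), compound 1 `COc1ccc(-c2c(Nc3ccc(C)cc3)c3ccc(OC)cc3oc2=O)cc1` gives 66900 nM, which lies within the scatter of both other measured values: compound 2 `COc1ccc(-c2c(Nc3ccc(NC(C)=O)cc3)c3ccc(OC)cc3oc2=O)cc1` at 85800 nM and compound 3 `COc1ccc(-c2c(Nc3cccc(C(F)(F)F)c3)c3ccc(OC)cc3oc2=O)cc1` at 36200 nM. Compound 4 `COc1ccc(-c2c(Nc3ccc(C)cc3)c3ccc(O)cc3oc2=O)cc1` is not yet measured and differs from compound 1 by hydrogen in place of methyl on an oxygen on an aromatic ring. Within the data shown here, no measured step touches that oxygen, since all three change the group on the nitrogen. They are a 1.3-fold higher number from compound 1 to compound 2 (0.11 log units; within the scatter) and a 1.8-fold lower number from compound 1 to compound 3 (0.27 log units; within the scatter), both within the scatter, and a 2.4-fold lower number from compound 2 to compound 3 (0.37 log units; beyond the scatter), modestly beyond it. These steps give only an indirect guide to size and none to direction. In this assay the expected step is a 1.3-fold lower number from compound 1 to compound 4 (0.13 log units; within the scatter), which would stay within the scatter. For compound 4 the estimate is 50000 nM, with an expected range from 20000 nM to 120000 nM.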

Compound 4, half-maximal inhibitory concentration: 85500 nM
The estimate for compound 4 lay 1.7-fold (0.23 log units) below the measured number, and the stated range covers the measured number.
By their numbers in this assay, from the lowest: compounds 3, 1, 4 and 2 (each within the scatter of the next, the first and the last beyond it).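

In this assay the change from methoxy to hydroxy gives a 1.3-fold higher number from compound 1 to compound 4 (0.11 log units; within the scatter) and is the first step shown at this oxygen rather than on the nitrogen. Removing the methyl here therefore leaves the number within the scatter, so on this core and with the 4-methylphenyl group in place, a free hydroxy and a methoxy cannot be told apart in this read-out. Nothing available explains this result.

Going by these compounds, whether an ethoxy group, a longer chain or an amine at this place would move the number beyond the scatter remains open. So does the same methoxy to hydroxy change on the other methoxy group of the compound.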